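Two Inactive Amides and a Diethylamino Follow-Up

This account rests on a few compounds, and the source may have more. Where it says the series, first, only, none or still open, it means among the compounds named here.

In a functional assay on MCF7 cells (Homo sapiens) for antiproliferative activity, read by MTT assay, with a stated time of 24 h (a higher number here means a weaker inhibitor, a lower number a stronger inhibitor), compound 1 `CCn1c(C(=O)N[C@H](C)C(=O)OC)ccc1C(CC)(CC)c1ccc(OCS(=O)(=O)c2ccccc2)c(C)c1` gives > 50000 nM, which is a limit and not a number. Compound 2 `CCn1c(C(=O)NCCNC(=O)OC(C)(C)C)ccc1C(CC)(CC)c1ccc(OCS(=O)(=O)c2ccccc2)c(C)c1` gives > 50000 nM in this assay, and this too is only a limit. Compound 2 therefore stands with no exact value, and the whole picture so far is the limit of > 50000 nM in this assay, at which 2 of the 2 values shown sit.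

Compound 3 `CCN(CC)CCNC(=O)c1ccc(C(CC)(CC)c2ccc(OCS(=O)(=O)c3ccccc3)c(C)c2)n1CC` differs from compound 2 at one place: diethylamino in place of (tert-butoxycarbonyl)amino on a saturated chain carbon, two bonds along the chain from an amide-type nitrogen. Diethylamino replaces (tert-butoxycarbonyl)amino on a saturated chain carbon, two bonds along the chain from an amide-type nitrogen.

For the measured compounds named here, the only measured step that bears on this change is a step that the two limits leave unreadable from compound 1 to compound 2. It alters the same amide-type nitrogen substituent but offers no size to carry over. No readable step is therefore expected with confidence, and a move toward stronger inhibition is the only direction this assay could show. The expected change is an at least 1.2-fold lower number from compound 2 to compound 3 (0.09 log units; that floor lies within the scatter). For compound 3 the estimated value is 40000 nM, with an expected range from 8000 nM to 100000 nM.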

Compound 3, half-maximal inhibitory concentration: 4680 nM
The estimate for compound 3 lay 8.5-fold (0.93 log units) above the measured number, and the stated range ends above it.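

Diethylamino in place of (tert-butoxycarbonyl)amino, on the saturated chain carbon two bonds along the chain from the amide-type nitrogen, brought a measurable number into this assay, with an at least 10-fold lower number from compound 2 to compound 3 (1.02 log units; beyond the scatter). The comparison with the other amide shows the same direction, with an at least 10-fold lower number from compound 1 to compound 3 (1.02 log units; beyond the scatter), so the substituent on this nitrogen can move the read-out by a large step while the rest of the molecule stays the same. The step between compound 1 and compound 2 cannot be read, and compound 3 alone has an exact value, while the other two compounds stand at a limit: the limit of > 50000 nM in this assay, at which 2 of the 3 values shown sit.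

The compounds shown do not tell whether the gain belongs to the diethylamino group itself or would also appear with a plain primary amine, a dimethylamino group, a piperidine or a morpholine at the end of the same chain. They also leave open what a longer chain between the amide-type nitrogen and the amine would do, and whether a carboxylic acid in that place would give any exact value at all.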